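Furan-2-yl for Benzylamino at the Carbonyl of Compound 2

The compounds below may be only part of what the source reports. "The series", "measured", "known", "first", "only" and "open" are said of these compounds alone.

Measured so far in a functional assay on MDA-MB-231 cells (Homo sapiens) for antiproliferative activity, read by MTT assay, with a stated time of 72 h; on this read-out lower numbers stand for stronger inhibition and higher numbers for weaker inhibition:
compound 1, `CC1=CC[C@H]2[C@@H]1CC=C(C)[C@@H](CC[C@H]1[C@]3(C)CC[C@H](OC(=O)c4ccccc4)C(C)(C)O[C@H]3CC[C@@]1(C)O)C2(C)C`, 18400 nM
compound 2, `CC1=CC[C@H]2[C@H](CC[C@]2(C)O)C(C)(C)[C@@H]1CC[C@H]1[C@]2(C)CC[C@H](OC(=O)NCc3ccccc3)C(C)(C)O[C@H]2CC[C@@]1(C)O`, 40300 nM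
compound 3, `CC1=CC[C@H]2[C@H](CC[C@]2(C)O)C(C)(C)[C@@H]1CC[C@H]1[C@]2(C)CC/C(=N/OC(=O)c3ccccc3)C(C)(C)O[C@H]2CC[C@@]1(C)O`, 27400 nM

Compound 2 carries the highest number of the three in this assay. Compound 3 stands nearest to it, and the gap between compound 2 and compound 3 lies within the usual scatter of such measurements, so the two cannot be told apart on these numbers. Compound 1 stands furthest from compound 2, with a lower number, and that gap reaches beyond the scatter.

Compound 4, `CC1=CC[C@H]2[C@H](CC[C@]2(C)O)C(C)(C)[C@@H]1CC[C@H]1[C@]2(C)CC[C@H](OC(=O)c3ccco3)C(C)(C)O[C@H]2CC[C@@]1(C)O`, has not yet been measured. It differs from compound 2 in one place:
furan-2-yl in place of benzylamino on a carbonyl carbon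

For the measured compounds named here, no pair of measured compounds differs in exactly one place, so no measured step stands as a guide for this change. Compound 1 and compound 3, each bearing a benzoyl-type group at a comparable position, return lower numbers than compound 2, which suggests that the direction for compound 4 may also be toward a lower number, though the amount is uncertain. The step from compound 2 to compound 4 is therefore expected to be modest, a 1.6-fold lower number from compound 2 to compound 4 (0.21 log units; within the scatter), and not clearly beyond the scatter. On that basis compound 4 is estimated to give 25000 nM in this assay, with a range from 10000 nM to 60000 nM.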

Compound 4, half-maximal inhibitory concentration: 14000 nM
Beside the measured number, compound 4's estimate is 1.8-fold (0.25 log units) above it; low and high end bracket the measured number.
By their numbers in this assay, from the lowest: compounds 4, 1, 3 and 2 (each within the scatter of the next, the first and the last beyond it).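

In this assay, the exchange of benzylamino for furan-2-yl on a carbonyl carbon gives a 2.9-fold lower number from compound 2 to compound 4 (0.46 log units; beyond the scatter) and is the only step among these compounds that can be read, so it is the first direct sign that the group on this carbonyl carbon affects the read-out on an otherwise unchanged molecule. The step changes several things at once: a six-membered aromatic ring of carbon gives way to a five-membered aromatic ring with one hetero atom, the heavy-atom count falls, and the hydrogen-bond donor of benzylamino is replaced by the single hydrogen-bond acceptor of furan-2-yl. No measurement at hand accounts for the step or shows which of these differences matters.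

The compounds shown do not separate the loss of the amino link from the change of ring, and a benzylamino group with its amide hydrogen replaced by a methyl group would address only the first of these. On these data alone, it also remains open how thiophen-2-yl, with sulfur in place of the ring oxygen, or a simple ethyl chain would read on this same carbonyl carbon.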